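The source may report more compounds than this note shows. Statements on the series, on what has been measured and on what is new or still open speak of the compounds shown alone.

Three compounds have been measured in an assay on isolated protein for agonist activity at Free fatty acid receptor 1 (Homo sapiens); a higher number here means that more compound is needed for the effect, a lower number that less compound is needed:

Compound 1 `CC#CC(CC(=O)O)c1ccc(OCc2ccc3nc(-c4ccccc4C)cn3c2)cc1` gives 389 nM.
Compound 2 `CC#CC(CC(=O)O)c1ccc(OCc2ccn3cc(-c4ccc(CC)cc4)nc3c2)cc1` gives 671 nM.
Compound 3 `CC#CC(CC(=O)O)c1ccc(OCc2ccn3cc(-c4cccc(C)c4)nc3c2)cc1` gives 1510 nM.

Compound 1 shows the lowest of the three numbers in this assay, though its gap to compound 2 lies within the scatter, while compound 3 sits well beyond it. Compound 4 `CC#CC(CC(=O)O)c1ccc(OCc2ccc3nc(-c4ccc(C(C)C)cc4)cn3c2)cc1` differs from compound 1 by a single exchange: 4-isopropylphenyl in place of 2-methylphenyl on an aromatic carbon. Going by the values given here, only one measured step bears on this exchange, and only loosely, since compound 2 and compound 3 carry their aryl group on a differently built core, as their structures show: a 2.3-fold higher number from compound 2 to compound 3 (0.35 log units; beyond the scatter). Among the compounds with values here, that step says a 4-ethylphenyl gave a lower number than a 3-methylphenyl, but no measured pair compares a 2-methylphenyl with a 4-alkylphenyl on the core of compound 1, and nothing measured speaks to an isopropyl group. A change in this assay of a 1.3-fold lower number from compound 1 to compound 4 (0.11 log units; within the scatter) is therefore expected, which is to say no step beyond the scatter in either direction. Compound 4 is estimated at 300 nM, with a likely range from 100 nM to 1000 nM.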

Compound 4, half-maximal effective concentration: 528 nM
Estimate against measurement, compound 4: 1.8-fold (0.25 log units) below, within the range that was stated.
By their numbers in this assay, from the lowest: compounds 1, 4 and 2 (each within the scatter of the next); then compound 3.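

In this assay, the exchange on the carbon of the five-membered ring gives a 1.4-fold higher number from compound 1 to compound 4 (0.13 log units; within the scatter), so on the core of compound 1 this position accepts either 2-methylphenyl or 4-isopropylphenyl with no change beyond the scatter. The entering group carries 9 heavy atoms against 7 and has its alkyl group at a different place on the phenyl ring, yet these differences together leave the number within the scatter. Nothing measured here explains why the two groups read alike.

All the aryl groups shown carry only small alkyl groups, so it remains open whether an amine or a methoxy group on the phenyl ring would hold the number. Also open, from the compounds shown here alone, is whether an unsubstituted phenyl at this position would read the same.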